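A few compounds are considered here, and "the series" means these few. Any claim that something is new, unique, unknown or untested is made for them only; others in the source may bear on it.

For the measured compounds named here, in an ADME assay on the whole organism (Rattus norvegicus) for pharmacokinetics, at a dose of 1 mg/kg by the intravenous route (on this read-out lower numbers stand for slow clearance and higher numbers for fast clearance), two compounds have numbers so far: compound 1 `Cc1nnc(N2CCC(C(=O)N3N=CC[C@H]3c3ccccc3)CC2)o1` gives 18 mL/min/kg and compound 2 `N#Cc1cnc(N2CCC(C(=O)N3N=CC[C@H]3c3cc(F)cc(F)c3)CC2)cn1` gives 47 mL/min/kg as the higher of the two, with the gap between them beyond the scatter. These two compounds differ in more than one place, so that gap cannot be assigned to any single change.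

Compound 3 `Cc1nnc(N2CCC(C(=O)N3N=CC[C@H]3c3cc(F)cc(F)c3)CC2)o1` differs from compound 2 in one place, on an amine nitrogen in a ring, with 5-methyl-1,3,4-oxadiazol-2-yl in place of 5-cyanopyrazin-2-yl on an amine nitrogen in a ring as the whole change. Going by the values given here, the only guide to this swap is compound 1, which carries the same 5-methyl-1,3,4-oxadiazol-2-yl group and gives 18 mL/min/kg on a structure that also differs from compound 3 elsewhere.

Among the compounds with values here, on that basis a fall in this assay is expected, and the estimated 2.1-fold lower number from compound 2 to compound 3 (0.33 log units; beyond the scatter) lies just beyond the scatter, although no measured pair isolates this change. For compound 3 the estimated value is 22 mL/min/kg within an expected range from 11 mL/min/kg to 42 mL/min/kg on this read-out.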

Compound 3, clearance: 14 mL/min/kg
Beside the measured number, compound 3's estimate is 1.6-fold (0.20 log units) above it; measured number inside the range.
By their numbers in this assay, from the lowest: compounds 3 and 1 (each within the scatter of the next); then compound 2.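

In this assay, for the compounds shown here, 5-methyl-1,3,4-oxadiazol-2-yl in place of 5-cyanopyrazin-2-yl on an amine nitrogen in a ring gives a 3.4-fold lower number from compound 2 to compound 3 (0.53 log units; beyond the scatter), the first reading of this position with the rest of the structure held constant. With that group fixed, 3,5-difluorophenyl in place of phenyl on a saturated ring carbon gives a 1.3-fold lower number from compound 1 to compound 3 (0.11 log units; within the scatter), so this pair shows no separable effect of the two fluorines on this read-out, and the gap between the first two compounds now has a one-place step at the amine nitrogen to set against it. Nothing available here accounts for the size of that step.

As far as these compounds go, each change rests on a single pair, so it remains open whether the step at the amine nitrogen would carry over to the plain phenyl compound, or whether the 3,5-difluorophenyl reading would hold with 5-cyanopyrazin-2-yl in place. Also open, from the compounds shown here alone, is how this read-out would respond to a longer alkyl chain in place of the methyl on the oxadiazole, or to a primary amine or carboxylic acid on that ring.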